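Aryl variation on the shared core: outlook for compound 4

A few compounds are considered here, and "the series" means these few. Any claim that something is new, unique, unknown or untested is made for them only; others in the source may bear on it.

Measured in a functional assay on HCT-116 cells (Homo sapiens) for inhibition, read by CCK-8 assay, with a stated time of 48 h; a lower number here means a stronger inhibitor, a higher number a weaker inhibitor:
compound 1 `COc1cc(-c2ccnc3cc(-c4ccc(C(C)=O)cc4)nn23)cc(OC)c1OC` gives 4390 nM
compound 2 `COc1cc(-c2ccnc3cc(-c4cn(C)c5ccccc45)nn23)cc(OC)c1OC` gives 762 nM
compound 3 `COc1cc(-c2ccnc3cc(-c4cccc(C)c4)nn23)cc(OC)c1OC` gives 6150 nM

Compound 3 carries the highest number of the three. Its nearest neighbour is compound 1, where the step of a 1.4-fold higher number from compound 1 to compound 3 (0.15 log units; within the scatter) lies within the scatter, so the two cannot be ordered. The step of an 8.1-fold higher number from compound 2 to compound 3 (0.91 log units; beyond the scatter) is beyond the scatter and is the only clear difference in this set.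

Compound 4 `C=Cc1ccc(-c2cc3nccc(-c4cc(OC)c(OC)c(OC)c4)n3n2)cc1` is not yet measured. Its change from compound 3 is 4-vinylphenyl in place of 3-methylphenyl on an aromatic carbon. The step that bears on it most directly is a 1.4-fold higher number from compound 1 to compound 3 (0.15 log units; within the scatter), where exchanging one substituted phenyl for another on the same aromatic carbon left the number within the scatter. The move into 4-vinylphenyl is again a change from one substituted phenyl to another, so no step beyond the scatter is expected in this assay, with a slight lean toward a lower number. For compound 4 the estimate is 5000 nM with a range of 2000 nM to 12000 nM, meaning an expected step of a 1.2-fold lower number from compound 3 to compound 4 (0.09 log units; within the scatter).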

Compound 4, half-maximal inhibitory concentration: 1060 nM
The estimate for compound 4 lay 4.7-fold (0.67 log units) above the measured number, and the stated range ends above it.
By their numbers in this assay, from the lowest: compounds 2 and 4 (each within the scatter of the next); then compounds 1 and 3 (each within the scatter of the next).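

In this assay, the step of a 5.8-fold lower number from compound 3 to compound 4 (0.76 log units; beyond the scatter) shows that exchanging one substituted phenyl for another on this aromatic carbon can move the number beyond the scatter, which the earlier step between two substituted phenyls did not show. The step of a 4.1-fold lower number from compound 1 to compound 4 (0.62 log units; beyond the scatter) points the same way, with vinyl and acetyl each attached to the phenyl group of otherwise matching compounds. With a 1.4-fold higher number from compound 2 to compound 4 (0.14 log units; within the scatter) the 4-vinylphenyl and 1-methyl-1H-indol-3-yl groups cannot be ordered, so the indole group is not the only one shown here with a number at this level. No measurement on hand explains these steps.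

The compounds shown do not separate the vinyl group from its place on the phenyl ring. A 4-ethylphenyl, 4-methylphenyl or 4-aminophenyl group would test how much depends on the vinyl group itself.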